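The compounds below may be only part of what the source reports. "The series", "measured", "known", "first", "only" and "open" are said of these compounds alone.

Compound 2 `O=C(NC1CCN(Cc2ccn(-c3ccc(C(F)(F)F)cc3)c2)CC1)N1CCCC1Cc1cccnc1` gives 26 nM in an assay on HEK293 cells for displacement of a labelled ligand from melanin-concentrating hormone receptor 1 (Homo sapiens); a lower number here means a stronger inhibitor, a higher number a weaker inhibitor. Compound 1 `CN1CCN(C(=O)NC2CCN(Cc3ccn(-c4ccc(C(F)(F)F)cc4)c3)CC2)C(c2ccccc2)C1` gives 28 nM in this assay, and the two values lie within the scatter of each other, so the numbers show no separation between them. Compound 3 `O=C(NC1CCN(Cc2ccn(-c3ccc(C(F)(F)F)cc3)c2)CC1)N1CCCC(CO)C1` has not yet been measured. It differs from compound 2 in one place: 3-(hydroxymethyl)piperidin-1-yl in place of 2-((pyridin-3-yl)methyl)pyrrolidin-1-yl on a carbonyl carbon. Among the measured compounds shown here, the two measured compounds carry different groups on the carbonyl carbon yet give similar values, but no measured pair here shows what losing the aromatic ring does. Compound 3 is expected to be weaker, a step of a 3.1-fold higher number from compound 2 to compound 3 (0.49 log units; beyond the scatter) beyond the scatter. The estimate for compound 3 is 80 nM, with a range from 25 nM to 300 nM.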

Compound 3, half-maximal inhibitory concentration: 23 nM
Compound 3: the middle estimate sits 3.5-fold (0.54 log units) above what was measured, and the stated range ends above it.
By their numbers in this assay, from the lowest: compounds 3, 2 and 1 (each within the scatter of the next).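

In this assay, placing 3-(hydroxymethyl)piperidin-1-yl on the carbonyl carbon gives a 1.1-fold lower number from compound 2 to compound 3 (0.05 log units; within the scatter). So at this position, an aromatic ring in the group is not required for a value in this range, even with fewer heavy atoms and a hydrogen-bond donor added. Nothing available explains why the values stay so close. The compounds shown leave open whether the hydroxymethyl group matters at all, since a plain piperidin-1-yl group would test that. A carboxylic acid in its place could also be informative.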